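The source may report more compounds than this note shows. Statements on the series, on what has been measured and on what is new or still open speak of the compounds shown alone.

Compound 1, `CCCn1c(=O)n(CCC(N)=O)c(=O)c2[nH]cnc21`, gives 13100 nM in a functional assay (trachea) with Cavia porcellus as the target; on this read-out higher numbers stand for an effect only at larger amounts of compound and lower numbers for an effect already at smaller amounts. Compound 2, `CCCn1c(=O)n(CCO)c(=O)c2[nH]cnc21`, gives 510 nM. Compound 3, `CCCn1c(=O)n(C)c(=O)c2[nH]cnc21`, gives 1600 nM.

Among these three numbers compound 3 stands second highest: there is a 3.1-fold higher number from compound 2 to compound 3 (0.50 log units; beyond the scatter) and an 8.2-fold lower number from compound 1 to compound 3 (0.91 log units; beyond the scatter). Compound 4, `CCCn1c(=O)n(C)c(=O)c2c1ncn2CCC(C)=O`, is not yet measured. It differs from compound 3 in one place: 2-acetylethyl in place of hydrogen on an aromatic nitrogen. Within the data shown here, every measured step alters the chain on the other ring nitrogen of the core, so no step among the three measured compounds bears on a change at this aromatic nitrogen of the five-membered ring. With nothing to point either way, the expectation for compound 4 is no step beyond the scatter, a 1.1-fold lower number from compound 3 to compound 4 (0.06 log units; within the scatter). Compound 4 is therefore estimated at 1400 nM, within 350 nM to 5500 nM.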

Compound 4, half-maximal effective concentration: 12200 nM
For compound 4 the middle estimate is 8.7-fold (0.94 log units) below the measured one, and the stated range ends below it.
By their numbers in this assay, from the lowest: compound 2; then compound 3; then compounds 4 and 1 (each within the scatter of the next).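

On the aromatic nitrogen of the five-membered ring, the change is not neutral: in this assay, 2-acetylethyl in place of hydrogen gives a 7.6-fold higher number from compound 3 to compound 4 (0.88 log units; beyond the scatter). This is the first change shown at this position, and it means that an effect then appears only at larger amounts of compound. No available evidence accounts for this step. Going by these compounds, it remains open whether the step follows from the carbonyl or from the length of the chain, and whether a methyl, an amine or a carboxylic acid on the same nitrogen would move the number in the same way.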